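Working notes: pendant swap on a shared core

The compounds below may be only part of what the source reports. "The series", "measured", "known", "first", "only" and "open" are said of these compounds alone.

Measured so far:
- compound 1, `C[Se]c1nc(N)c2ccccc2n1`: > 100000 nM in a functional assay on MCF7 cells (Homo sapiens) for cytotoxicity, read by MTT assay, with a stated time of 72 h (on this read-out lower numbers stand for stronger inhibition of growth and higher numbers for weaker inhibition of growth), a limit of the assay rather than a number.
- compound 2, `CSc1nc(NCCCc2ccccc2)c2ccccc2n1`: > 100000 nM in this assay, likewise a limit and not a number.

Compound 2 thus stands at the top edge of what this assay reports; neither value shown is a number, as the limit of > 100000 nM in this assay, at which 2 of the 2 values shown sit, makes plain. For the measured compounds named here, no step between measured compounds can be sized, and of compound 1 and compound 2 only this can be said: both sit at that limit.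

Compound 3, `CSc1nc(NCCCCCO)c2ccccc2n1`, differs from compound 2 by 2-hydroxyethyl in place of phenyl on a saturated chain carbon, three bonds along the chain from a nitrogen on an aromatic ring. With nothing to anchor a direction, the step from compound 2 to compound 3 is expected to lie within the scatter, as a step that the limit leaves unreadable from compound 2 to compound 3 in this assay. Compound 3 is accordingly estimated at 150000 nM, with a range from 50000 nM to 500000 nM, and most probably will again be reported only as a limit.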

Compound 3, concentration for total growth inhibition: > 100000 nM
Compound 3 was reported as a limit (the forecaster's own chance of this, stated with the estimate: 85%); the middle value does not contradict the limit.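

Compound 2 and compound 3 both give only a limit in this assay, so no step between them can be read: the limit of > 100000 nM in this assay, at which 3 of the 3 values shown sit.

The compounds shown leave open whether any pendant on the shared core brings growth inhibition into the range reported as a number.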